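High Clearance Scaffold: Swapping the Fused Bicyclic Amine

A few compounds are considered here, and "the series" means these few. Any claim that something is new, unique, unknown or untested is made for them only; others in the source may bear on it.

For the measured compounds named here, compound 1 `O=C1CCC(=O)N1Cc1cc2nccc(-c3cc(Cl)cc4c3O[C@@H](c3onc5c3CNCC5)C4)c2s1` is the only compound in this set with a number: in an ADME assay on the whole organism (Rattus norvegicus, strain Sprague-Dawley) for pharmacokinetics, at a dose of 0.5 mg/kg by the intravenous route (on this read-out higher numbers stand for fast clearance and lower numbers for slow clearance), compound 1 gives 96.7 mL/min/kg, which places it among rapidly cleared compounds. Compound 2 `Cc1cc(Cl)cc(-c2ccnc3cc(CN4C(=O)C5CC5C4=O)sc23)c1O[C@@H]1CCNC[C@@H]1C` shares the core but in this assay its result is "not determined" (no result reported), so no comparison with compound 1 can be drawn from it. Compound 3 `Cn1nc2c(c1[C@H]1Cc3cc(Cl)cc(-c4ccnc5cc(CN6C(=O)CCC6=O)sc45)c3O1)CNCC2` differs from compound 1 by a group of 10 heavy atoms (7 carbon, 3 nitrogen; one five-membered aromatic ring with 2 hetero atoms, one six-membered non-aromatic ring with 1 hetero atom) in place of a group of 9 heavy atoms (6 carbon, 2 nitrogen, 1 oxygen; one five-membered aromatic ring with 2 hetero atoms, one six-membered non-aromatic ring with 1 hetero atom), on a saturated ring carbon. Going by the values given here, with no measured step of this kind on which to lean, the author expects that the exchange of one fused bicyclic amine for another of closely matched size leaves the read-out roughly where it is: the step from compound 1 to compound 3 is estimated at a 1.1-fold lower number from compound 1 to compound 3 (0.06 log units; within the scatter), which is within the ordinary scatter of the assay rather than a real change. Compound 3 is therefore expected to show a clearance of about 85 mL/min/kg, with a plausible range from 40 mL/min/kg to 160 mL/min/kg.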

Compound 3, clearance: 78.3 mL/min/kg
Compound 3: the middle estimate sits 1.1-fold (0.04 log units) above what was measured, within the range that was stated.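

For the compounds shown here, the first measured step at this position, on a saturated ring carbon next to the ring oxygen, is a 1.2-fold lower number from compound 1 to compound 3 (0.09 log units; within the scatter) in this assay. A group of 10 heavy atoms (7 carbon, 3 nitrogen) can therefore stand in place of a group of 9 heavy atoms (6 carbon, 2 nitrogen, 1 oxygen) without separating the two compounds on this read-out, and both groups hold the same ring types and the same counts of donors and acceptors. No measurement shown here accounts for this result.

Going by these compounds alone, the step tests only one closely matched pair of fused groups, so it remains open whether an open-chain amine or a carboxylic acid on this carbon would give a step beyond the scatter. It also leaves open whether any change elsewhere on the shared core would do so.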